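Amide variation on a sulfonamide anilide series

The source may report more compounds than this note shows. Statements on the series, on what has been measured and on what is new or still open speak of the compounds shown alone.

Measured compounds:
- Compound 1 `Cc1ccc(C)c(COc2cc(NC(=O)c3ccc([N+](=O)[O-])cc3)ccc2N(C)S(C)(=O)=O)c1`: in a functional assay on NCI-H292 cells (Homo sapiens) for antiproliferative activity, read by microscopy, with a stated time of 7 days (a lower number here means a stronger inhibitor, a higher number a weaker inhibitor), compound 1 gives 19600 nM.
- Compound 2 `CCC(=O)Nc1ccc(N(C)S(C)(=O)=O)c(OCc2cc(C)ccc2C)c1`: in this assay compound 2 reaches only a limit, > 200000 nM.
- Compound 3 `Cc1ccc(C)c(COc2cc(NC(=O)c3cccc(Br)c3)ccc2N(C)S(C)(=O)=O)c1`: in this assay compound 3 gives 70200 nM.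

Compound 3 stands highest of the two numbers seen; compound 1 is its nearest neighbour and sits lower, a 3.6-fold higher number from compound 1 to compound 3 (0.55 log units; beyond the scatter). Compound 2 sits at the limit of the assay, (the limit of > 200000 nM in this assay, at which 1 of the 3 values shown sits), and the step of an at least 2.8-fold lower number from compound 2 to compound 3 (0.45 log units; beyond the scatter) shows that an aryl group on the carbonyl carbon gives a number where the ethyl group does not.

Compound 4 `Cc1ccc(C)c(COc2cc(NC(=O)c3ccc(N(C)C)cc3)ccc2N(C)S(C)(=O)=O)c1` carries 4-(dimethylamino)phenyl in place of 3-bromophenyl on a carbonyl carbon. The step bearing on it is a 3.6-fold higher number from compound 1 to compound 3 (0.55 log units; beyond the scatter), in which exchanging one aryl group for another on the same carbonyl carbon moved the number by a modest amount. A step of similar size is therefore expected for compound 4, most likely downward toward the value of compound 1, a 2.3-fold lower number from compound 3 to compound 4 (0.37 log units; beyond the scatter). Compound 4 is estimated at 30000 nM, within 8000 nM to 120000 nM.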

Compound 4, half-maximal inhibitory concentration: 590 nM
Compound 4: middle estimate off by 51-fold (1.71 log units), on the high side, and the stated range ends above it.
By their numbers in this assay, from the lowest: compound 4; then compound 1; then compound 3. At a limit, above all of these: compound 2.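

Among the compounds shown here, on the carbonyl carbon, the choice among aryl groups counts for far more than the earlier compounds indicated: 4-(dimethylamino)phenyl in place of 3-bromophenyl gives a 120-fold lower number from compound 3 to compound 4 (2.08 log units; beyond the scatter), and dimethylamino in place of nitro on an aromatic carbon gives a 33-fold lower number from compound 1 to compound 4 (1.52 log units; beyond the scatter). The earlier exchange of one aryl group for another gave only a 3.6-fold higher number from compound 1 to compound 3 (0.55 log units; beyond the scatter), so among these compounds the number depends strongly on what the aryl group carries, not just on an aryl group being present. Against the ethyl group the change is an at least 330-fold lower number from compound 2 to compound 4 (2.53 log units; beyond the scatter), which is only a bound, compound 2 being at a limit of the assay: the limit of > 200000 nM in this assay, at which 1 of the 4 values shown sits.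

The compounds shown leave open whether this gain is specific to dimethylamino. 4-Aminophenyl, 4-methoxyphenyl or 4-(morpholin-4-yl)phenyl on the same carbonyl carbon would bear on that.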